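The source may report more compounds than this note shows. Statements on the series, on what has been measured and on what is new or still open speak of the compounds shown alone.

Measured in an ADME assay on microsomes from liver (Mus musculus) for metabolic stability, read by LC-MS, with NADPH named in the record, with a stated time of 60 min, tested at 1 uM, in the absence of a further agent (a lower number here means that less of the compound is left, a higher number that more of the compound is left), each value a limit of the assay:
- Compound 1 `COc1ccc(-c2c(C)nc3c(N4CC[C@@H](NS(=O)(=O)C(C)C)C4)cc(C)nn23)cc1OC`: > 95%
- Compound 2 `COc1ccc(-c2c(C)nc3c(N4CCCC4)cc(C)nn23)cc1OC`: > 95%
- Compound 3 `COc1ccc(-c2c(C)nc3c(N4CC[C@@H](O)C4)cc(C)nn23)cc1OC`: > 95%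

Compound 3 stands at the limit of > 95% in this assay, at which 3 of the 3 values shown sit. Compound 4 `COc1ccc(-c2c(C)nc3c(N4CC[C@@H](N=[N+]=[N-])C4)cc(C)nn23)cc1OC` carries azido in place of hydroxy on a saturated ring carbon, 3-hydroxypyrrolidin-1-yl to 3-azidopyrrolidin-1-yl (azido in place of hydroxy on a saturated ring carbon). Two measured changes at the same carbon bear on this: a step that the two limits leave unreadable from compound 2 to compound 3 and a step that the two limits leave unreadable from compound 1 to compound 3. Neither gives a size, but hydrogen, hydroxy and (isopropylsulfonyl)amino all leave this assay at the limit. From the compounds shown here alone, the expected change is a number at least 3 percentage points lower from compound 3 to compound 4 (that floor lies within the scatter), none beyond the scatter, though azido itself is untested here. For compound 4 the estimated value is 92%, with an expected range of 72% to 100%.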

Compound 4, percent of the compound remaining: > 95%
Compound 4: only a limit was reported; the forecaster's own chance of this, stated with the estimate: 55%; middle value at least 3 percentage points away from the limit.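

Within the data shown here, compound 4 sits at the assay limit, as do compounds 1, 2 and 3, so no step to compound 4 can be read: the limit of > 95% in this assay, at which 4 of the 4 values shown sit. The compounds shown leave open whether any group on this saturated ring carbon changes the result in this assay.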